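A few compounds are considered here, and "the series" means these few. Any claim that something is new, unique, unknown or untested is made for them only; others in the source may bear on it.

In a functional assay on A549 cells (Homo sapiens) for antiproliferative activity, read by MTT assay, with a stated time of 48 h (on this read-out lower numbers stand for stronger inhibition and higher numbers for weaker inhibition), compound 1 (`CCN(CC)CCn1c(N)c(-c2nc3ccccc3[nH]2)c2nc(C#N)c(C#N)nc21`) gives > 50000 nM as a limit of the assay, not a number. Compound 2 (`N#Cc1nc2c(-c3nc4ccccc4[nH]3)c(N)n(CCO)c2nc1C#N`) gives > 50000 nM as a limit too, so its place on the scale is known only as that limit (the limit of > 50000 nM in this assay, at which 2 of the 2 values shown sit). Compound 3 (`N#Cc1nc2c(-c3nc4ccccc4[nH]3)c(N)n(CCCN3CCCCC3)c2nc1C#N`) is still unmeasured. It differs from compound 2 by (piperidin-1-yl)methyl in place of hydroxy on a saturated chain carbon, two bonds along the chain from an aromatic nitrogen with (piperidin-1-yl)methyl in place of hydroxy on a saturated chain carbon, two bonds along the chain from an aromatic nitrogen. Within the data shown here, the one measured step at this place is a step that the two limits leave unreadable from compound 1 to compound 2 and offers no size to carry over. Compound 1 already bears diethylamino on its chain and still gives the limit > 50000 nM in this assay, so no clear gain is expected from the new chain. The expected change is a number no higher from compound 2 to compound 3 (the limit leaves the size open) in this assay, with no step beyond the scatter foreseen in either direction. Compound 3 is estimated at 50000 nM with an expected range from 15000 nM to 100000 nM and a good chance of another limit.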

Compound 3, half-maximal inhibitory concentration: 6110 nM
Beside the measured number, compound 3's estimate is 8.2-fold (0.91 log units) above it; measured number below the stated range.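

In this assay, among these compounds, the group on this chain can change the result: the move to 3-(piperidin-1-yl)propyl gives an at least 8.1-fold lower number from compound 2 to compound 3 (0.91 log units; beyond the scatter), the first step here with a readable size, as the step between the two earlier compounds cannot be read. Having an amine on the chain does not settle the outcome alone, since (piperidin-1-yl)methyl in place of diethylamino gives an at least 8.1-fold lower number from compound 1 to compound 3 (0.91 log units; beyond the scatter). The two earlier compounds could show only a shared limit of the assay, not a number: the limit of > 50000 nM in this assay, at which 2 of the 3 values shown sit.

The compounds shown do not separate the part played by the piperidine ring from that of the longer chain, a question that 2-(piperidin-1-yl)ethyl at this place would help to answer. As far as these compounds go, how a morpholine ring at the end of the same chain would read in this assay also remains open.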